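The source may hold more compounds than are shown below. What is called first, only, known or untested is meant among the compounds shown, and "the series" means these compounds.

The study looks at two measured compounds and one that awaits measurement in an ADME assay on WI-38 cells (Homo sapiens) for cytotoxicity, read by MTT assay, with a stated time of 48 h; a higher number here means a weaker inhibitor, a lower number a stronger inhibitor. Compound 1, with the structure `N=C(N)c1ccc(-c2ccc(-c3cc(Cl)cc(Cl)c3)s2)s1`, gives 98800 nM in this assay. Compound 2, with the structure `N=C(N)c1ccc(-c2ccc(-c3ccccc3)s2)s1`, gives 49100 nM in this assay, the lowest of the two numbers shown, although the gap to compound 1 lies within the scatter, so no order between the two can be claimed. Compound 3, with the structure `COc1ccc(-c2ccc(-c3ccc(C(=N)N)s3)s2)cc1`, has not yet been measured. It differs from compound 2 by methoxy in place of hydrogen on an aromatic carbon. Among the measured compounds shown here, no step between measured compounds is available for comparison, so the size of the step in this assay is open. Given the closeness of compound 1 and compound 2, the expected step of a 1.1-fold higher number from compound 2 to compound 3 (0.05 log units; within the scatter) is small and in no clear direction, not beyond the scatter. Compound 3 is therefore expected to give about 55000 nM in this assay, within a range from 20000 nM to 150000 nM.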

Compound 3, half-maximal inhibitory concentration: 12900 nM
For compound 3 the middle estimate is 4.3-fold (0.63 log units) above the measured one, outside the stated range (below it).
By their numbers in this assay, from the lowest: compound 3; then compounds 2 and 1 (each within the scatter of the next).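

In this assay, methoxy in place of hydrogen on an aromatic carbon, para to a large group, gives a 3.8-fold lower number from compound 2 to compound 3 (0.58 log units; beyond the scatter) and lies beyond the scatter. Among the compounds shown here, this is the first step available between compounds that differ in one place, and it shows that the number in this assay can move with a single change at this position of the six-membered aromatic ring. No measurement at hand bears on what lies behind the step.

From the compounds shown here alone, it remains open whether the step is particular to methoxy or would also follow from another group at this position, such as a hydroxyl, an amine or a longer ether chain like ethoxy. Going by these compounds, it is equally open whether methoxy placed elsewhere on this ring would give a step of similar size.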